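A few compounds are considered here, and "the series" means these few. Any claim that something is new, unique, unknown or untested is made for them only; others in the source may bear on it.

Three compounds of this series already have numbers in an assay on HEK293 cells for displacement of a labelled ligand from 5-hydroxytryptamine receptor 7 (Homo sapiens), with a stated time of 1 h; a lower number here means a stronger inhibitor, a higher number a weaker inhibitor. Compound 1 `NC(=O)[C@@H]1CCCN1C(=O)CCCCCN1CCN(c2ccc(F)cc2)CC1` gives 1190 nM, compound 2 `NC(=O)[C@@H]1CCCN1C(=O)CCCCCN1CCN(c2noc3ccccc23)CC1` gives 50 nM, and compound 3 `CSc1ccccc1N1CCN(CCCCC(=O)N2Cc3ccccc3C[C@H]2C(N)=O)CC1` gives 51 nM. Compound 3 thus stands second highest of the three: its number and that of compound 2 lie within the scatter of each other, while its gap to compound 1 lies beyond it. Among the measured compounds shown here, the only step between neighbours that differ in a single place is a 24-fold lower number from compound 1 to compound 2 (1.38 log units; beyond the scatter), in which a larger aromatic group took the place of the 4-fluorophenyl on an amine nitrogen in a ring.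

Compound 4 `NC(=O)[C@@H]1Cc2ccccc2CN1C(=O)CCCCN1CCN(c2ccc(F)cc2)CC1` is not yet measured. It differs from compound 3 in one place: 4-fluorophenyl in place of 2-(methylsulfanyl)phenyl on an amine nitrogen in a ring. The step from compound 1 to compound 2 bears on this change in reverse, as it shows how the 4-fluorophenyl fares against a larger aromatic group on the same kind of ring nitrogen, and that step was large. Compound 1, which bears the 4-fluorophenyl, also gives the highest number of the three, 1190 nM. The core of compound 4 differs from that of compound 1, so the full size of that step need not carry over. Compound 4 is therefore expected to give a higher number than compound 3, a 7.8-fold higher number from compound 3 to compound 4 (0.89 log units; beyond the scatter). Compound 4 is estimated at 400 nM, with a range from 120 nM to 1300 nM.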

Compound 4, inhibition constant: 295 nM
For compound 4 the middle estimate is 1.4-fold (0.13 log units) above the measured one, and the stated range covers the measured number.
By their numbers in this assay, from the lowest: compounds 2 and 3 (each within the scatter of the next); then compound 4; then compound 1.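

In this assay, exchanging the 2-(methylsulfanyl)phenyl for 4-fluorophenyl on an amine nitrogen in a ring gives a 5.8-fold higher number from compound 3 to compound 4 (0.76 log units; beyond the scatter), so this change now has a direct reading on a core other than that of compound 1. The 4-fluorophenyl compound also carries the higher number in the earlier pair, a 24-fold lower number from compound 1 to compound 2 (1.38 log units; beyond the scatter), and neither pair goes against this, although the two steps differ in the group opposed to the 4-fluorophenyl and in the core, so their sizes cannot be set directly against each other. Nothing measured here accounts for the step.

The compounds shown leave open how a plain phenyl or a 2-methoxyphenyl on the same ring nitrogen would stand against these two groups, and so whether the step follows from losing the methylsulfanyl group, from gaining the fluorine, or from both. They also leave open whether the larger aromatic group of compound 2 would give a lower number than the 2-(methylsulfanyl)phenyl on the core of compound 3.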